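The source may report more compounds than this note shows. Statements on the series, on what has been measured and on what is new or still open speak of the compounds shown alone.

Measured so far:
compound 1, `CC(C)=CCC/C(C)=C/CC/C(C)=C/CSC[C@H](NC(=O)CCCCCN1CCN(C)CC1)C(=O)NC1CCCCCC1`: 6200 nM
compound 2, `CC(C)=CCC/C(C)=C/CC/C(C)=C/CSC[C@H](NC(=O)CCCCCN1CCCC1)C(=O)NC1CCCCCC1`: 5800 nM
compound 3, `CC(C)=CCC/C(C)=C/CC/C(C)=C/CSc1ccccc1C(N)=O`: > 20000 nM

Within the data shown here, in a functional assay on BXPC-3 cells (Homo sapiens) for cytotoxicity, read by fluorescence, with a stated time of 48 h (on this read-out lower numbers stand for an effect already at smaller amounts and higher numbers for an effect only at larger amounts of compound), compound 2 gives 5800 nM, one of only two numbers in this set. The other number comes from compound 1, and the step of a 1.1-fold lower number from compound 1 to compound 2 (0.03 log units; within the scatter) lies within the scatter. For compound 3 the read-out is a limit, > 20000 nM (the limit of > 20000 nM in this assay, at which 1 of the 3 values shown sits).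

Compound 4, `CC(C)=CCC/C(C)=C/CC/C(C)=C/CSC[C@H](NC(=O)CCCCCN1CCCC1)C(=O)N1CCCC1`, differs from compound 2 by pyrrolidin-1-yl in place of cycloheptylamino on a carbonyl carbon. Among the measured compounds shown here, no measured step touches the carbonyl carbon where this change sits; the one step given, from compound 1 to compound 2, sits on a saturated chain carbon five bonds from the carbonyl carbon and was within the scatter. The data therefore give no direction for the new step, and the expectation is a step of a 1.2-fold higher number from compound 2 to compound 4 (0.08 log units; within the scatter), with a wide range allowed for either direction.

Compound 4 is expected to give 7000 nM in this assay, between 2500 nM and 18000 nM.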

Compound 4, half-maximal effective concentration: 6500 nM
Beside the measured number, compound 4's estimate is 1.1-fold (0.03 log units) above it; low and high end bracket the measured number.
By their numbers in this assay, from the lowest: compounds 2, 1 and 4 (each within the scatter of the next). At a limit, above all of these: compound 3.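

First change on the carbonyl carbon: in this assay, a 1.1-fold higher number from compound 2 to compound 4 (0.05 log units; within the scatter), so replacing cycloheptylamino with pyrrolidin-1-yl leaves the number within the scatter. The seven-membered carbon ring and the amide hydrogen are thus not needed at this position to keep the read-out in this range, at least with pyrrolidin-1-yl on the saturated chain carbon. Nothing measured here speaks to a cause for this step.

Still open, on these data alone, is whether a carboxylic acid or a dimethylamino group on the same carbonyl carbon would keep the number in this range, or whether a larger group such as a substituted piperidine would do so. Also open, as far as these compounds go, is whether the change from cycloheptylamino to pyrrolidin-1-yl would give a similar step with 4-methylpiperazin-1-yl on the chain.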